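Isoxazole series: replacing the (vinylamino)methyl arm

The source may hold more compounds than are shown below. What is called first, only, known or untested is meant among the compounds shown, and "the series" means these compounds.

Measured so far:
compound 1 `C=CNCc1cc(-c2c(C(=O)NCC)noc2-c2cc(C(C)C)c(O)cc2O)on1`: 121 nM
compound 2 `CCNC(=O)c1noc(-c2cc(C(C)C)c(O)cc2O)c1-c1cc(CNC(=O)CC)no1`: 78 nM

In a functional assay on HCT-116 cells (Homo sapiens) for inhibition (a higher number here means a weaker inhibitor, a lower number a stronger inhibitor), compound 1 gives 121 nM, the highest of the two numbers; its nearest neighbour is compound 2, and the step of a 1.6-fold lower number from compound 1 to compound 2 (0.19 log units; within the scatter) lies within the scatter, so the two stand level. Compound 3 `CCNC(=O)c1noc(-c2cc(C(C)C)c(O)cc2O)c1-c1cc(C(=O)NC)no1` has not been measured. It differs from compound 1 as follows: methylcarbamoyl in place of (vinylamino)methyl on an aromatic carbon. For the measured compounds named here, the only measured step, a 1.6-fold lower number from compound 1 to compound 2 (0.19 log units; within the scatter), changes the group on the amine nitrogen in the same arm and moves nothing beyond the scatter. Going by the values given here, no measured step exchanges the whole arm for methylcarbamoyl, so the expectation rests on that single neighbouring step and a wide range is kept. The expected step is a 1.1-fold lower number from compound 1 to compound 3 (0.04 log units; within the scatter), in no particular direction beyond the scatter. Compound 3 is therefore estimated at 110 nM, with a range from 40 nM to 320 nM.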

Compound 3, half-maximal inhibitory concentration: 124 nM
Estimate against measurement, compound 3: 1.1-fold (0.05 log units) below; measured number inside the range.
By their numbers in this assay, from the lowest: compounds 2, 1 and 3 (each within the scatter of the next).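

In this assay the whole (vinylamino)methyl arm on the aromatic carbon gives way to methylcarbamoyl with a 1.0-fold higher number from compound 1 to compound 3 (0.01 log units; within the scatter), so this exchange of the full arm leaves the two compounds level, whereas the earlier pair differed only in the group on the amine nitrogen. Set against the (propanoylamino)methyl arm, methylcarbamoyl gives a 1.6-fold higher number from compound 2 to compound 3 (0.20 log units; within the scatter), and all three arms therefore stand level at this position in this assay. No evidence on the origin of this flat reading is available.

Open, as far as these compounds go, is whether a carboxylic acid or a primary aminomethyl arm on this carbon would also stand level with these three. Equally open, from the compounds shown here alone, is whether a longer chain on the amide nitrogen of the methylcarbamoyl arm would move the number beyond the scatter.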